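Urea to Benzamide on the Shared Core

The compounds below may be only part of what the source reports. "The series", "measured", "known", "first", "only" and "open" are said of these compounds alone.

In a functional assay on HCT-15 cells (Homo sapiens) for inhibition, read by sulforhodamine B assay, with a stated time of 48 h (a lower number here means a stronger inhibitor of growth, a higher number a weaker inhibitor of growth), compound 3 `COc1cc(-c2nn(-c3cccc(NC(=O)Nc4cccc(C(F)(F)F)c4)c3)cc2-c2ccncc2)ccc1Cl` gives 870 nM, standing second highest of the three numbers: compound 2 `COc1cc(-c2nn(-c3cccc(NC(=O)Nc4cc(C(F)(F)F)cc(C(F)(F)F)c4)c3)cc2-c2ccncc2)ccc1Cl` gives 617 nM and compound 1 `O=C(Nc1cccc(-n2cc(-c3ccncc3)c(-c3ccc(Cl)c(O)c3)n2)c1)Nc1cccc(C(F)(F)F)c1` gives 1510 nM. Both measured steps sit within the scatter: a 1.7-fold lower number from compound 1 to compound 3 (0.24 log units; within the scatter) and a 1.4-fold higher number from compound 2 to compound 3 (0.15 log units; within the scatter). Compound 4 `COc1cc(-c2nn(-c3cccc(NC(=O)c4ccccc4)c3)cc2-c2ccncc2)ccc1Cl` differs from compound 3 by phenyl in place of (3-(trifluoromethyl)phenyl)amino on a carbonyl carbon. Within the data shown here, neither measured step touches this part of the structure, so no direct precedent exists; the change is larger than either measured one, and a weakening step beyond the scatter is expected in this assay, though with wide uncertainty. Compound 4 is therefore estimated at 2500 nM, within 800 nM to 8000 nM, an expected step of a 2.9-fold higher number from compound 3 to compound 4 (0.46 log units; beyond the scatter).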

Compound 4, concentration for 50% growth inhibition: 654 nM
Compound 4: the middle estimate sits 3.8-fold (0.58 log units) above what was measured, outside the stated range (below it).
By their numbers in this assay, from the lowest: compounds 2, 4, 3 and 1 (each within the scatter of the next, the first and the last beyond it).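

In this assay the position on the carbonyl carbon accepts a large change, with a 1.3-fold lower number from compound 3 to compound 4 (0.12 log units; within the scatter) on putting phenyl in place of (3-(trifluoromethyl)phenyl)amino. The amino nitrogen, its hydrogen-bond donor and the trifluoromethyl thus leave together without moving the number beyond the scatter. Nothing measured on these compounds bears on the reason for this result. The compounds shown leave open whether the phenyl of compound 4 would keep this level when it carries a trifluoromethyl, an amine or a carboxylic acid. Also open, from the compounds shown here alone, is a longer chain on that carbonyl carbon, such as benzyl.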